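Phenoxy to dimethylamino on the hydroxy-bearing series

The source may hold more compounds than are shown below. What is called first, only, known or untested is meant among the compounds shown, and "the series" means these compounds.

Of the compounds shown here, three with a shared core have been measured in a functional assay on OVCAR-3 cells (Homo sapiens) for cytotoxicity, read by sulforhodamine B assay, with a stated time of 48 h, tested at 0.001 uM; a higher number here means a weaker effect of the compound at the concentration tested, a lower number a stronger effect. Compound 1 `COc1cc(C)cc(-c2nn(CC#N)cc2-c2ccc(-c3cccc(C(C)=O)c3)nc2)c1` gives 102% in this assay. Compound 3 `COc1cc(C)cc(-c2nn(CC#N)cc2-c2ccnc(-c3ccc(N(C)C)cc3)c2)c1` gives 106% in this assay. Compound 2 `Cc1cc(O)cc(-c2nn(CC#N)cc2-c2ccnc(-c3ccc(Oc4ccccc4)cc3)c2)c1` gives 92% in this assay, the lowest of the three numbers; its gap to compound 1 lies within the scatter, its gap to compound 3 lies beyond it. No pair among these three differs in only one place, so no single step can be read from them.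

Compound 4 `Cc1cc(O)cc(-c2nn(CC#N)cc2-c2ccnc(-c3ccc(N(C)C)cc3)c2)c1` is not yet measured. It differs from compound 2 in one place: dimethylamino in place of phenoxy on an aromatic carbon. Compound 3 carries the same dimethylamino group and sits near the top of the range seen so far.

The step from compound 2 to compound 4 in this assay is expected to be small and upward, estimated as a number 8 percentage points higher from compound 2 to compound 4 (within the scatter), not clearly beyond the scatter. Compound 4 is expected to give about 100% in this assay, within a range from 90% to 110%.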

Compound 4, a percentage reported as activity, at one concentration (the size of the read-out at that concentration, not a potency): 105%
Beside the measured number, compound 4's estimate is 5 percentage points below it, within the range that was stated.
By their numbers in this assay, from the lowest: compounds 2, 1, 4 and 3 (each within the scatter of the next, the first and the last beyond it).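

In this assay, within the data shown here, the first single-place change at this position, a number 13 percentage points higher from compound 2 to compound 4 (beyond the scatter), separates phenoxy from dimethylamino on this aromatic carbon, para to a large group, with the lower number going with phenoxy. The second step, a number 1 percentage points lower from compound 3 to compound 4 (within the scatter), replaces a methyl on an oxygen on an aromatic ring with hydrogen and shows that, with dimethylamino in place, this change leaves the read-out within the scatter. Nothing available gives a reason for either step.

Open, on these data alone, is whether the phenoxy effect holds when that oxygen carries methyl, and whether a benzyloxy group or a cyclic amine such as morpholine on the same carbon would follow phenoxy or dimethylamino. A read-out at one concentration also leaves the potency of these compounds open.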